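The source may hold more compounds than are shown below. What is called first, only, known or untested is meant among the compounds shown, and "the series" means these compounds.

Compound 1 `Cc1cc(Nc2cc(-c3ccccc3)[nH]n2)n2nc(SCCCc3ccccc3)nc2n1` gives 5030 nM in a functional assay on PC-9 cells (Homo sapiens) for inhibition, read by MTT assay, with a stated time of 72 h; on this read-out higher numbers stand for weaker inhibition and lower numbers for stronger inhibition.
Compound 3 `Cc1cc(Nc2cc(-c3ccccc3)[nH]n2)n2nc(SCc3ccc(Br)cc3)nc2n1` gives 4760 nM in this assay.
Compound 2 `CCCSc1nc2nc(C)cc(Nc3cc(-c4ccccc4)[nH]n3)n2n1` gives > 50000 nM in this assay, which is a limit of the assay and not a number.

Of the two numbers shown, compound 3 has the lowest, but compound 1 lies within the scatter of it, as a 1.1-fold lower number from compound 1 to compound 3 (0.02 log units; within the scatter) shows. Compound 4 `C=CCSc1nc2nc(C)cc(Nc3cc(-c4ccccc4)[nH]n3)n2n1` is not yet measured in this assay; it differs from compound 3 in one place: vinyl in place of 4-bromophenyl on a saturated chain carbon bound to a sulfur. Going by the values given here, two measured steps bear on this change. The step of an at least 10-fold lower number from compound 2 to compound 3 (1.02 log units; beyond the scatter) shows that placing an aromatic ring on the chain carbon bound to the sulfur gave a large fall in the number, and the step of an at least 9.9-fold higher number from compound 1 to compound 2 (0.99 log units; beyond the scatter) shows that taking a phenyl off the chain gave a rise of at least the same order. Compound 4 keeps only a short chain without a ring, so a large rise in the number is expected, a 6.3-fold higher number from compound 3 to compound 4 (0.80 log units; beyond the scatter). Compound 4 is therefore estimated at 30000 nM in this assay, within 8000 nM to 100000 nM, and it is expected that the assay may report only a limit, as it did for compound 2.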

Compound 4, half-maximal inhibitory concentration: > 50000 nM
Compound 4 ended at the assay's limit (the forecaster's own chance of this, stated with the estimate: 45%); middle value at least 1.6-fold (0.22 log units) from the limit.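

In this assay, vinyl in place of 4-bromophenyl on the saturated chain carbon bound to a sulfur gives an at least 10-fold higher number from compound 3 to compound 4 (1.02 log units; beyond the scatter), and vinyl in place of phenethyl at the same carbon gives an at least 9.9-fold higher number from compound 1 to compound 4 (0.99 log units; beyond the scatter). A double bond in the short chain therefore does not bring back what the ring-bearing chains show: among the compounds shown, only compound 1 and compound 3, which carry a ring on the chain, give readable numbers, and no compound goes against this. Compound 4, like compound 2, ends at a limit of the assay and not at a number, so the step between them cannot be read: the limit of > 50000 nM in this assay, at which 2 of the 4 values shown sit.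

As far as these compounds go, how far past the limit either ring-free compound lies stays open, so ethyl and vinyl cannot be ranked. Also open, from the compounds shown here alone, is whether an amine or a carboxylic acid at the end of a longer chain could take the place of the ring.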